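The compounds below may be only part of what the source reports. "The series", "measured", "known", "first", "only" and "open" are said of these compounds alone.

Measured so far in a functional assay on PC-3 cells (Homo sapiens) for antiproliferative activity, read by sulforhodamine B assay, with a stated time of 48 h; a higher number here means a weaker inhibitor, a lower number a stronger inhibitor: compound 1 `CC(C)(C)OC(=O)NCCC[C@@H]1N=C2C[C@@H]3C[C@@H](C3(C)C)[C@]2(C)OC1=O` gives 6600 nM; compound 2 `CC(C)(C)OC(=O)NCCCC[C@H]1N=C2C[C@H]3C[C@H](C3(C)C)[C@@]2(C)OC1=O` gives 15900 nM.

Compound 2 has the highest of the two numbers, and compound 1 sits at a lower number, beyond the usual scatter. Compound 3 `CC(C)(C)OC(=O)NCCCC[C@@H]1N=C2C[C@@H]3C[C@@H](C3(C)C)[C@]2(C)OC1=O` is the mirror image of compound 2: the two compounds have the same atoms and bonds and differ only in configuration as drawn: 4 of 4 stereo elements differ (all stereocentres are inverted: mirror images); a stereocentre at a saturated ring carbon is drawn R in compound 2 and S in compound 3; a stereocentre at a saturated ring carbon is drawn R in compound 2 and S in compound 3; a stereocentre at a saturated ring carbon is drawn R in compound 2 and S in compound 3; a stereocentre at a saturated ring carbon is drawn R in compound 2 and S in compound 3. Among the measured compounds shown here, no measured pair shows what such a full inversion does here, so only a loose expectation is possible: a modest step, more likely toward a lower number than a higher one, but not reliably beyond the scatter. Compound 3 is therefore estimated at 8000 nM, with a range from 2500 nM to 25000 nM, meaning an expected step of a 2.0-fold lower number from compound 2 to compound 3 (0.30 log units; within the scatter).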

Compound 3, half-maximal inhibitory concentration: 18000 nM
For compound 3 the middle estimate is 2.3-fold (0.35 log units) below the measured one; the measured number falls inside the stated range.
By their numbers in this assay, from the lowest: compound 1; then compounds 2 and 3 (each within the scatter of the next).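

In this assay, the mirror-image pair shows a 1.1-fold higher number from compound 2 to compound 3 (0.05 log units; within the scatter), so full inversion of the stereocentres does not separate these two compounds. This is a direct test of handedness alone: the fact that compounds 2 and 3 differ only in the configuration as drawn. With the drawn configuration matched, ((tert-butoxycarbonyl)amino)methyl in place of (tert-butoxycarbonyl)amino gives a 2.7-fold higher number from compound 1 to compound 3 (0.44 log units; beyond the scatter), a modest step tied to the chain alone. As far as these compounds go, whether the mirror image of compound 1 would match compound 1 remains open. So does the effect of a free amine or a carboxylic acid at the chain end.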